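Swapping a hydroxyl for chlorine on the pendant phenyl ring

The compounds below may be only part of what the source reports. "The series", "measured", "known", "first", "only" and "open" are said of these compounds alone.

Compound 1 `Cn1cnc2c(N3CCCCC3)nc(-c3ccccc3O)nc21` was tested in an assay on cells for displacement of a labelled ligand from adenosine receptor A3 (Homo sapiens), read by scintillation counting and radioligand binding, with a stated time of 180 min, tested at 10 uM (on this read-out higher numbers stand for more inhibition at the one concentration tested (going by the name of the read-out) and lower numbers for less inhibition), and in this assay compound 1 gives 20%. Compound 2 `CN1CCN(c2nc(-c3ccccc3O)nc3c2ncn3C)CC1` carries a 4-methylpiperazin-1-yl group where compound 1 has a piperidin-1-yl group; in this assay compound 2 gives 15.3%. The step of a number 4.7 percentage points lower from compound 1 to compound 2 (within the scatter) is too small to count as a real change. A third compound, compound 3 `CN1CCN(c2nc(-c3cccc(O)c3)nc3[nH]cnc23)CC1`, was also measured. In this assay compound 3 reaches > 80%, which is a limit of the assay rather than a number, and the limit of > 80% in this assay, at which 1 of the 3 values shown sits, marks where this limit sits. Among the two plain numbers, compound 1 stands highest, with compound 2 within the scatter of it.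

Compound 4 `Cn1cnc2c(N3CCCCC3)nc(-c3cccc(Cl)c3)nc21` differs from compound 1 in one place: 3-chlorophenyl in place of 2-hydroxyphenyl on an aromatic carbon. Among the measured compounds shown here, no measured step in this assay changes the pendant phenyl ring, so none bears directly on this swap; the only measured step alters the amine on the shared core and lies within the scatter. The expectation is therefore uncertain, with a wide range. The step of a number 10 percentage points higher from compound 1 to compound 4 (within the scatter) is expected to be modest. For compound 4 the estimate in this assay is 30%, with a range from 5% to 65%.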

Compound 4, a percentage reported as inhibition, at one concentration (the size of the read-out at that concentration, not a potency): 6.1%
For compound 4 the middle estimate is 23.9 percentage points above the measured one; measured number inside the range.
By their numbers in this assay, from the lowest: compounds 4, 2 and 1 (each within the scatter of the next, the first and the last beyond it). At a limit, above all of these: compound 3.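

The pendant phenyl ring is a place where a change can be read: with 3-chlorophenyl in place of 2-hydroxyphenyl, this assay shows a number 13.9 percentage points lower from compound 1 to compound 4 (beyond the scatter), whereas the earlier change to the amine gave only a number 4.7 percentage points lower from compound 1 to compound 2 (within the scatter). This single swap alters two things at once, since hydroxyl gives way to chlorine and the substituent's place on the ring also differs, and the step alone does not separate the two. Nothing measured here accounts for the lower number.

From the compounds shown here alone, it remains open whether the loss follows the change of group or the change of place on the ring, and 2-chlorophenyl or 3-hydroxyphenyl on the core of compound 1 would separate the two. Also open, going by these compounds, is how other groups at this place, such as an amine in 3-aminophenyl or a carboxylic acid in 3-carboxyphenyl, would read at this single concentration, which gives the size of the inhibition and not a potency.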